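Swapping the acyl aryl group on an arginine-derived core

The compounds below may be only part of what the source reports. "The series", "measured", "known", "first", "only" and "open" are said of these compounds alone.

Compound 1: `N=C(N)NCCC[C@@H](NC(=O)c1cc2ccccc2cn1)C(=O)NCc1ccc(C(F)(F)F)cc1` — 1810 nM
Compound 2: `N=C(N)NCCC[C@@H](NC(=O)c1cc2cc(F)ccc2[nH]1)C(=O)NCc1ccc(C(F)(F)F)cc1` — 25 nM
Compound 3: `N=C(N)NCCC[C@@H](NC(=O)c1ccc(F)c2ccccc12)C(=O)NCc1ccc(C(F)(F)F)cc1` — 311 nM

Three compounds share a core and differ only in the aryl group on the carbonyl carbon. In a functional assay on HEK293 cells for antagonist activity at melanin-concentrating hormone receptor 1 (Homo sapiens) (on this read-out higher numbers stand for weaker inhibition and lower numbers for stronger inhibition), compound 2 gives 25 nM, compound 1 gives 1810 nM, and compound 3 gives 311 nM, the second highest of the three. The steps are substantial: a 72-fold lower number from compound 1 to compound 2 (1.86 log units; beyond the scatter), a 5.8-fold lower number from compound 1 to compound 3 (0.76 log units; beyond the scatter), and a 12-fold higher number from compound 2 to compound 3 (1.09 log units; beyond the scatter).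

Compound 4, `N=C(N)NCCC[C@@H](NC(=O)c1ccc2ccccc2c1)C(=O)NCc1ccc(C(F)(F)F)cc1`, differs from compound 3 by the change (naphthalen-2-yl in place of 4-fluoronaphthalen-1-yl on a carbonyl carbon). Among the measured compounds shown here, no measured step involves naphthalen-2-yl, so the three steps bear on it only indirectly: they show that exchanging the aryl group at this position moves this assay by a large amount in either direction. The move from compound 3 to compound 4 keeps two six-membered carbon rings and removes the fluorine, which is a smaller alteration than any step seen so far.

Compound 4 is therefore expected to give about 400 nM in this assay, with a range from 80 nM to 2000 nM, which is a step of a 1.3-fold higher number from compound 3 to compound 4 (0.11 log units; within the scatter) and is estimated to stay close to compound 3.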

Compound 4, half-maximal inhibitory concentration: 212 nM
For compound 4 the middle estimate is 1.9-fold (0.28 log units) above the measured one, and the stated range covers the measured number.
By their numbers in this assay, from the lowest: compound 2; then compounds 4 and 3 (each within the scatter of the next); then compound 1.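

In this assay the exchange of 4-fluoronaphthalen-1-yl for naphthalen-2-yl gives a 1.5-fold lower number from compound 3 to compound 4 (0.17 log units; within the scatter) and so does not separate the two groups, even though the fluorine is gone and the two names differ in the point of attachment. With an 8.5-fold higher number from compound 2 to compound 4 (0.93 log units; beyond the scatter) and an 8.5-fold lower number from compound 1 to compound 4 (0.93 log units; beyond the scatter) the naphthalen-2-yl group stays clearly apart from the other two aryl groups, so the two groups built from carbon rings alone sit together, with compound 2 on one side and compound 1 on the other. Nothing shown here explains these differences.

On these data alone, whether the fluorine of compound 2 matters to its number remains open. So does how a plain 1H-indol-2-yl or a naphthalen-1-yl group without fluorine would read at this position.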